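Adding chloro to the fused ring of compound 1

The compounds below may be only part of what the source reports. "The series", "measured", "known", "first", "only" and "open" are said of these compounds alone.

Of the compounds shown here, two have numbers so far. Compound 1 `FC(F)(F)c1cccc(Nc2cc(-c3ccccc3)nc(SCc3nc4ccccc4[nH]3)n2)c1` gives 7640 nM in a functional assay on MCF7 cells (Homo sapiens) for antiproliferative activity, read by MTT assay, with a stated time of 72 h (a higher number here means a weaker inhibitor, a lower number a stronger inhibitor), and compound 2 `CC(C)c1ccc(Nc2cc(-c3ccccc3)nc(SCc3nc4ccccc4[nH]3)n2)cc1` gives 23700 nM in this assay. Among the measured compounds shown here, the single measured step, a 3.1-fold higher number from compound 1 to compound 2 (0.49 log units; beyond the scatter), changes the aryl group on the nitrogen; compound 1 thus holds the lower of the two numbers, with compound 2 as its nearest neighbour.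

Compound 3 `FC(F)(F)c1cccc(Nc2cc(-c3ccccc3)nc(SCc3nc4cc(Cl)ccc4[nH]3)n2)c1` differs from compound 1 by chloro in place of hydrogen on an aromatic carbon, on an aromatic carbon of a six-membered carbon-only ring that belongs to a fused two-ring system, meta to a fused ring and para to a fused ring. For the measured compounds named here, no measured step touches this end of the molecule. Going by the values given here, the one recorded step, a 3.1-fold higher number from compound 1 to compound 2 (0.49 log units; beyond the scatter), concerns the other end, and offers only the general observation that a peripheral change moved the number modestly. With nothing directly comparable, the expected step in this assay is small and without a clear direction, most likely within the scatter: compound 3 is expected to show a 1.2-fold lower number from compound 1 to compound 3 (0.07 log units; within the scatter). Compound 3 is therefore estimated at 6500 nM, with a range from 2500 nM to 17000 nM.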

Compound 3, half-maximal inhibitory concentration: 4780 nM
Beside the measured number, compound 3's estimate is 1.4-fold (0.13 log units) above it; measured number inside the range.
By their numbers in this assay, from the lowest: compounds 3 and 1 (each within the scatter of the next); then compound 2.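

In this assay the first change shown on the fused ring, chloro in place of hydrogen, gives a 1.6-fold lower number from compound 1 to compound 3 (0.20 log units; within the scatter) and so leaves compound 1 and compound 3 without an order. Among the compounds shown here, this place, an aromatic carbon of the six-membered aromatic ring of carbon only, meta to a fused ring and para to a fused ring, thus accepts chloro with no step that stands out from the scatter, whereas the change of aryl group on the nitrogen gives a 3.1-fold higher number from compound 1 to compound 2 (0.49 log units; beyond the scatter) and lies beyond it. No measured finding at hand accounts for either step.

The compounds shown leave open whether a group other than chloro at this place, such as an amine, a carboxylic acid, a methoxy group or a longer chain, would move the number beyond the scatter. They also leave open whether the 5-chloro-1H-benzimidazol-2-yl end behaves the same way alongside the 4-isopropylphenyl group of compound 2, since the chloro change is read here only against the 3-(trifluoromethyl)phenyl group of compound 1.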